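The source may hold more compounds than are shown below. What is called first, only, known or untested is meant among the compounds shown, and "the series" means these compounds.

Two compounds have been measured so far:
compound 1 `CCCOCNc1n[n+]([O-])c2cc(OC)ccc2[n+]1[O-]` — 10600 nM in a functional assay on PC-3 cells (Homo sapiens) for cytotoxicity, read by MTT assay, with a stated time of 72 h; on this read-out lower numbers stand for stronger inhibition and higher numbers for weaker inhibition
compound 2 `CCCCOCNc1n[n+]([O-])c2ccccc2[n+]1[O-]` — 6010 nM in this assay

Compound 2 has the lowest of the two numbers in this assay; its nearest neighbour is compound 1, whose number is higher by an amount that falls within the usual scatter, so the two cannot be ranked against each other. Compound 3 `CCCCCCCOCNc1n[n+]([O-])c2ccccc2[n+]1[O-]` has not yet been measured. It differs from compound 2 in one place: propyl in place of hydrogen on a saturated chain carbon, four bonds along the chain from an oxygen on a saturated carbon. Among the compounds with values here, no step between two measured compounds shows what such a change does to the read-out of this assay; compound 1 and compound 2 differ in more than one place, so their values show only that both lie in the same region. Within the data shown here, with no step to lean on, the change from compound 2 to compound 3 is expected to leave the number roughly where it stands, with at most a small move downward, not clearly beyond the scatter. Compound 3 is therefore estimated at 4500 nM, within the range 1500 nM to 13000 nM. That corresponds to an expected step of a 1.3-fold lower number from compound 2 to compound 3 (0.13 log units; within the scatter).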

Compound 3, half-maximal inhibitory concentration: 390 nM
Compound 3: middle estimate off by 12-fold (1.06 log units), on the high side; measured number below the stated range.
By their numbers in this assay, from the lowest: compound 3; then compounds 2 and 1 (each within the scatter of the next).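

At the saturated chain carbon four bonds along the chain from an oxygen on a saturated carbon, the read-out of this assay proves highly responsive: propyl in place of hydrogen gives a 15-fold lower number from compound 2 to compound 3 (1.19 log units; beyond the scatter) and so moves the number well beyond the scatter. Within the data shown here, the earlier compounds placed two values in the same region but offered no single-place step, so this is the first change whose effect can be read, and it shows that an addition of carbon alone, with no ring, no hydrogen-bond donors or acceptors and no net charge, can produce a large step here. No measurement at hand accounts for the size of this step.

Among these compounds, with only this one step at the position, it remains open whether methyl or ethyl in place of hydrogen would yield part of the same move or whether it appears only with propyl. Going by these compounds, it is equally open whether a longer chain would lower the number further or reverse the trend, and whether an amine or a carboxylic acid at the end of the chain would keep any of the gain.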